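What to Expect When Nitro Becomes Amino

The source may hold more compounds than are shown below. What is called first, only, known or untested is meant among the compounds shown, and "the series" means these compounds.

Three compounds share one core and differ only in a single group on an aromatic carbon. Compound 1 `CC(C)(CCCCOc1cc(-c2ccc(C(F)(F)F)cc2)c2ccccc2n1)C(=O)O` carries a trifluoromethyl group there, and in an assay on membranes from spleen (Cavia porcellus) for binding affinity to leukotriene B4 receptor 1 (Homo sapiens) (a lower number here means a stronger inhibitor, a higher number a weaker inhibitor), compound 1 gives 300 nM. Compound 2 `Cc1ccc(-c2cc(OCCCCC(C)(C)C(=O)O)nc3ccccc23)cc1` carries a methyl group, and in this assay compound 2 gives 30 nM. Compound 3 `CC(C)(CCCCOc1cc(-c2ccc([N+](=O)[O-])cc2)c2ccccc2n1)C(=O)O` carries a nitro group, and in this assay compound 3 gives 150 nM, the second highest of the three numbers; its gap to compound 1 lies within the scatter, while a 5.0-fold higher number from compound 2 to compound 3 (0.70 log units; beyond the scatter).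

Compound 4 `CC(C)(CCCCOc1cc(-c2ccc(N)cc2)c2ccccc2n1)C(=O)O` is the next member: amino in place of nitro on an aromatic carbon. For the measured compounds named here, none of the measured steps swaps nitro for amino. The nearest guides are a 2.0-fold lower number from compound 1 to compound 3 (0.30 log units; within the scatter) and a 5.0-fold higher number from compound 2 to compound 3 (0.70 log units; beyond the scatter), which show that one change at this carbon can move the number modestly or leave it within the scatter. Amino resembles none of these groups, so no direction can be read from them. The estimate for compound 4 is therefore 150 nM, with a range of 40 nM to 600 nM, which means an expected step of no change at the digits printed from compound 3 to compound 4 (within the scatter).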

Compound 4, half-maximal inhibitory concentration: 40 nM
Estimate against measurement, compound 4: 3.8-fold (0.57 log units) above, within the range that was stated.
By their numbers in this assay, from the lowest: compounds 2 and 4 (each within the scatter of the next); then compounds 3 and 1 (each within the scatter of the next).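

In this assay, amino in place of nitro gives a 3.8-fold lower number from compound 3 to compound 4 (0.57 log units; beyond the scatter), so this swap at the carbon para to a large group moves the number beyond the scatter. The other two steps sort the four groups into two sets: a 1.3-fold higher number from compound 2 to compound 4 (0.12 log units; within the scatter) leaves amino and methyl within the scatter of each other, while a 7.5-fold lower number from compound 1 to compound 4 (0.88 log units; beyond the scatter) separates amino from trifluoromethyl, and nitro and trifluoromethyl were already within the scatter of each other. No measurement shown here accounts for why the groups divide this way.

On these data alone, the division rests on just four groups, so it remains open where a hydroxyl, a methoxy or an acetylated amine would fall. Also open, as far as these compounds go, is whether a methylamino or dimethylamino group would stay level with amino.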